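A few compounds are considered here, and "the series" means these few. Any claim that something is new, unique, unknown or untested is made for them only; others in the source may bear on it.

Compound 1 `Cc1ccc(Cn2c(CN3CCN(C(=O)C4CC4)CC3)nc3ccccc32)cc1`: 51.5%
Compound 2 `O=C(C1CC1)N1CCN(Cc2nc3ccccc3n2Cc2ccccc2)CC1`: 23.9%
Compound 3 `O=C(C1CC1)N1CCN(Cc2nc3ccccc3n2Cc2ccc(Cl)cc2)CC1`: 56.6%

In an assay on isolated protein for inhibition of aldehyde dehydrogenase 1A1 (Homo sapiens), read by spectrophotometry, tested at 10 uM (on this read-out higher numbers stand for more inhibition at the one concentration tested (going by the name of the read-out) and lower numbers for less inhibition), compound 3 gives 56.6%. Compound 1 lies a number 5.1 percentage points higher from compound 1 to compound 3 (within the scatter), so the two are not separated; compound 2 lies a number 32.7 percentage points higher from compound 2 to compound 3 (beyond the scatter). Compound 4 `CC(C)CCn1c(CN2CCN(C(=O)C3CC3)CC2)nc2ccccc21` differs from compound 3 by isobutyl in place of 4-chlorophenyl on a saturated chain carbon bound to an aromatic nitrogen. Among the compounds with values here, no measured step removes the aromatic ring altogether; the nearest comparisons are the loss of the ring substituent, a number 27.6 percentage points lower from compound 1 to compound 2 (beyond the scatter) and a number 32.7 percentage points higher from compound 2 to compound 3 (beyond the scatter), both of which leave the bare benzyl compound well down. Replacing the whole 4-chlorophenyl with isobutyl is a larger change than either, and a drop of at least that order is expected, a number 36.6 percentage points lower from compound 3 to compound 4 (beyond the scatter). The estimate for compound 4 in this assay is 20%, within 0% to 45%.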

Compound 4, a percentage reported as inhibition, at one concentration (the size of the read-out at that concentration, not a potency): 70%
Beside the measured number, compound 4's estimate is 50 percentage points below it; measured number outside the range, above it.
By their numbers in this assay, from the lowest: compound 2; then compounds 1 and 3 (each within the scatter of the next); then compound 4.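

In this assay an aromatic ring is not needed on the saturated chain carbon bound to an aromatic nitrogen: isobutyl in place of 4-chlorophenyl gives a number 13.4 percentage points higher from compound 3 to compound 4 (beyond the scatter) and in place of 4-methylphenyl gives a number 18.5 percentage points higher from compound 1 to compound 4 (beyond the scatter) while in place of phenyl it gives a number 46.1 percentage points higher from compound 2 to compound 4 (beyond the scatter). All three steps lie beyond the scatter, so among these four compounds the group without a ring outranks every group with one. No supporting data bear on why this happens. On these data alone, whether a longer chain or a terminal amine at this place holds the number stays open. So does whether a saturated ring such as cyclohexyl behaves like isobutyl or like phenyl.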